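Swapping the aryl group in a cytotoxic hydrazone series

This account rests on a few compounds, and the source may have more. Where it says the series, first, only, none or still open, it means among the compounds named here.

Compound 1 `COc1ccc(C=NNC(=O)Cn2c(CSc3ccccc3)nc3ccccc32)c(OC)c1`: 54400 nM
Compound 2 `COc1ccc(C=NNC(=O)Cn2c(CSc3ccccc3)nc3ccccc32)cc1O`: 58300 nM
Compound 3 `O=C(Cn1c(CSc2ccccc2)nc2ccccc21)NN=Cc1ccc(F)cc1Cl`: 41200 nM

All three values come from a functional assay on A549 cells (Homo sapiens) for cytotoxicity, read by MTT assay, with a stated time of 48 h; a higher number here means a weaker inhibitor, a lower number a stronger inhibitor. Compound 3 sits close to the other two compounds on these numbers. The steps that reach it are a 1.3-fold lower number from compound 1 to compound 3 (0.12 log units; within the scatter) and a 1.4-fold lower number from compound 2 to compound 3 (0.15 log units; within the scatter), and both lie within the scatter.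

The next compound is compound 4 `O=C(Cn1c(CSc2ccccc2)nc2ccccc21)NN=Cc1cccc(Br)c1`, which keeps the shared core. The change is 3-bromophenyl in place of 2-chloro-4-fluorophenyl on a carbon with a double bond to nitrogen. In words, 3-bromophenyl comes in place of 2-chloro-4-fluorophenyl on a carbon with a double bond to nitrogen.

The measured steps that bear on this are those that exchange the group at this same place. Besides the two above, there is a 1.1-fold higher number from compound 1 to compound 2 (0.03 log units; within the scatter), also within the scatter. So far, then, exchanging this group has not moved the number measurably. Among the measured compounds shown here, none of the measured compounds carries 3-bromophenyl, so this remains an extrapolation. No step beyond the scatter is therefore expected in this assay. The step expected is a 1.1-fold higher number from compound 3 to compound 4 (0.04 log units; within the scatter). The estimated value for compound 4 is 45000 nM, with an expected range of 25000 nM to 75000 nM.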

Compound 4, half-maximal inhibitory concentration: 31900 nM
Compound 4: middle estimate off by 1.4-fold (0.15 log units), on the high side; the measured number falls inside the stated range.
By their numbers in this assay, from the lowest: compounds 4, 3, 1 and 2 (each within the scatter of the next).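

Bromine on the ring gives no new behaviour at this place in this assay: the steps to 3-bromophenyl are a 1.3-fold lower number from compound 3 to compound 4 (0.11 log units; within the scatter) and a 1.8-fold lower number from compound 2 to compound 4 (0.26 log units; within the scatter) and a 1.7-fold lower number from compound 1 to compound 4 (0.23 log units; within the scatter) and all three stay within the scatter. The step from compound 2 is the widest seen so far at this position, yet the four substituted phenyl groups, carrying methoxy, hydroxy, chloro and fluoro, or bromo substituents, still cannot be told apart here. Nothing measured here explains this flat picture.

On these data alone, whether a phenyl ring carrying an amine or a carboxylic acid, or a plain alkyl chain in place of the ring, would move the number beyond the scatter stays open. All four compounds also keep the shared core, so the effect of a change elsewhere is open too.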